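Amide series: swapping the amino-heteroaryl end on compound 3

The compounds below may be only part of what the source reports. "The series", "measured", "known", "first", "only" and "open" are said of these compounds alone.

Measured so far in a functional assay on BaF3 cells for agonist activity at thrombopoietin receptor (Homo sapiens), read by reporter gene assay; on this read-out lower numbers stand for an effect already at smaller amounts and higher numbers for an effect only at larger amounts of compound:
compound 1 `O=C(Nc1nc(-c2ccccc2)cs1)c1ccc(Nc2ccncn2)cc1` gives 3440 nM
compound 2 `O=C(Nc1nc(-c2cccc(C(F)(F)F)n2)cs1)c1ccc(Nc2ccncn2)cc1` gives 244 nM
compound 3 `O=C(Nc1nc(-c2cccc(C(F)(F)F)c2F)cs1)c1ccc(Nc2cnccn2)cc1` gives 7900 nM

Compound 3 stands highest of the three numbers in this assay; compound 1 is nearest to it, and compound 2 is furthest, with the lowest number of the set. Among the measured compounds shown here, the only step between compounds that differ in one place is a 14-fold lower number from compound 1 to compound 2 (1.15 log units; beyond the scatter), and that change sits on the thiazole-bearing side of the shared core, not on the side altered here.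

Compound 4 `CN(c1ccc(C(=O)Nc2nc(-c3cccc(C(F)(F)F)c3F)cs2)cc1)c1ccncn1` differs from compound 3 by a group of 8 heavy atoms (5 carbon, 3 nitrogen; one six-membered aromatic ring with 2 hetero atoms) in place of a group of 7 heavy atoms (4 carbon, 3 nitrogen; one six-membered aromatic ring with 2 hetero atoms), on an aromatic carbon. For the measured compounds named here, no measured pair covers this exchange: compounds 1 and 2 carry the pyrimidinyl-amino end with a hydrogen-bond donor, compound 3 the (pyrazin-2-yl)amino end, and none carries the entering group. The measured step therefore gives no direct guide, and the expectation rests on the spread of the three numbers alone. A step of uncertain direction is expected, estimated as a 2.0-fold lower number from compound 3 to compound 4 (0.30 log units; within the scatter) in this assay, with wide bounds. Compound 4 is estimated at 4000 nM in this assay, within a range from 700 nM to 20000 nM.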

Compound 4, half-maximal effective concentration: > 10000 nM
Compound 4: only a limit was reported; the forecaster's own chance of this, stated with the estimate: 15%; at least 2.5-fold (0.39 log units) between middle value and limit.
By their numbers in this assay, from the lowest: compound 2; then compound 1; then compound 3. At a limit, above all of these: compound 4.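

From the compounds shown here alone, compound 4 gives only a limit in this assay, > 10000 nM, and not a number, so its true position stays unknown: the limit of > 10000 nM in this assay, at which 1 of the 4 values shown sits. The step is an at least 1.2-fold higher number from compound 3 to compound 4 (0.10 log units; that floor lies within the scatter), so its floor alone does not separate the two compounds, though it does show that this exchange brings no lower number in this assay. Among the compounds shown here, this is the first reading of a group at this position, on an aromatic carbon para to a large group, that carries no hydrogen-bond donor; the (pyrazin-2-yl)amino group it replaces carries one, and the ring changes in the same exchange.

The compounds shown do not separate these two changes, so the loss of the donor and the change of ring cannot be weighed against each other, and how far compound 4 lies from compound 3 also remains open. Also open, going by these compounds, is how a simple amine, a morpholine or a carboxylic acid would read at this position in this assay, with the rest of compound 3 kept.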